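The source may hold more compounds than are shown below. What is called first, only, known or untested is meant among the compounds shown, and "the series" means these compounds.

Measured so far:
- compound 1, `COc1cc(-c2cc(/C=C/C(=O)c3ccc(Cl)c(Cl)c3)[nH]n2)cc(OC)c1OC`, 62%
- compound 2, `COc1ccc(C(=O)/C=C/c2cc(-c3cc(OC)c(OC)c(OC)c3)n[nH]2)cc1`, 78%

Among the measured compounds shown here, in a functional assay on T47D cells (Homo sapiens) for cytotoxicity, read by sulforhodamine B assay, with a stated time of 48 h, tested at 1 uM (on this read-out lower numbers stand for a stronger effect and higher numbers for a weaker effect at the one concentration tested), compound 2 gives the higher of the two numbers known so far, its nearest neighbour being compound 1 with 62%, a gap that lies beyond the scatter. For the measured compounds named here, the one step measured, a number 16 percentage points higher from compound 1 to compound 2 (beyond the scatter), was a modest rise produced by placing 4-methoxyphenyl in place of 3,4-dichlorophenyl on the carbonyl carbon.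

Compound 3 is `COc1cc(-c2cc(/C=C/C(=O)c3ccc(F)c(F)c3)[nH]n2)cc(OC)c1OC`, not yet measured in this assay. It differs from compound 2 as follows: 3,4-difluorophenyl in place of 4-methoxyphenyl on a carbonyl carbon. Going by the values given here, this change runs opposite to the one step known: the 4-methoxyphenyl leaves again and a dihalogenated ring enters, though with fluorine rather than chlorine. The step from compound 1 to compound 2 therefore bears on it directly. A fall in the number is expected for compound 3, of a size near that of the earlier step, possibly somewhat smaller since the halogen differs; the expected step is a number 12 percentage points lower from compound 2 to compound 3 (beyond the scatter). The estimate for compound 3 in this assay is 66%, with a range from 52% to 80%.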

Compound 3, a percentage reported as activity, at one concentration (the size of the read-out at that concentration, not a potency): 76%
The estimate for compound 3 lay 10 percentage points below the measured number; the range from low to high includes it.
By their numbers in this assay, from the lowest: compound 1; then compounds 3 and 2 (each within the scatter of the next).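

In this assay the exchange of 4-methoxyphenyl for 3,4-difluorophenyl on the carbonyl carbon gives a number 2 percentage points lower from compound 2 to compound 3 (within the scatter) and so leaves the two groups indistinguishable here, which means that a ring carrying two halogens does not by itself go with the lower number. The exchange of halogen alone, 3,4-difluorophenyl in place of 3,4-dichlorophenyl, gives a number 14 percentage points higher from compound 1 to compound 3 (beyond the scatter) and ties the stronger effect of compound 1 to 3,4-dichlorophenyl among these three groups, with compound 3 going against any reading based on halogens in general. No measurement at hand accounts for this difference between the two dihalogenated groups.

The compounds shown leave open whether the lower number needs both chlorine atoms and whether heavier halogens extend it, which a monochlorophenyl and a dibromophenyl group on the carbonyl carbon would test, while an aminophenyl group would show how a ring bearing an amine behaves at this place. Each number also comes from a single concentration, so the order among these compounds gives no potency.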